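A few compounds are considered here, and "the series" means these few. Any claim that something is new, unique, unknown or untested is made for them only; others in the source may bear on it.

Measured compounds in a toxicity assay on THP-1 cells (Homo sapiens) for inhibition; a higher number here means that more compound is tolerated, a lower number that less compound is tolerated:
Compound 1 `COc1ccc(-c2cnc(NC(=O)C3CCNCC3)n2C)cc1` is reported only as a limit, > 100000 nM.
Compound 2 `COc1ccc(-c2cnc(NC(=O)c3ccccc3C#N)n2C)cc1` is reported only as a limit, > 100000 nM.
Compound 3 `COc1ccc(-c2cnc3nc(-c4ccc(F)cc4)[nH]c3c2)cc1` is reported only as a limit, > 100000 nM.

Compound 2 therefore stands at the limit of this assay, with no number of its own; the same holds for the two other values shown, which sit at the limit of > 100000 nM in this assay, at which 3 of the 3 values shown sit. Among the measured compounds shown here, the one measured step, a step that the two limits leave unreadable from compound 1 to compound 2, is unreadable for that reason, so it gives no sizable direction.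

Compound 4 `COc1ccc(-c2cnc(NC(=O)c3ccccn3)n2C)cc1` differs from compound 2 by pyridin-2-yl in place of 2-cyanophenyl on a carbonyl carbon. For the measured compounds named here, no measured step bears readably on this change; the only guide is that every value, including compound 2, sits at the limit. Compound 4 is expected to remain at that limit, a step of a number no higher from compound 2 to compound 4 (the limit leaves the size open) that is not beyond the scatter. The estimate for compound 4 in this assay is 100000 nM, with a range from 50000 nM to 200000 nM.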

Compound 4, half-maximal cytotoxic concentration: > 100000 nM
Compound 4: a limit, no number; the forecaster's own chance of this, stated with the estimate: 85%; the middle value sits exactly at the limit.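

In this assay compound 4 gives > 100000 nM, a limit and not a number. Its steps from compound 1 and compound 2 cannot be read. The compounds shown leave open at what concentration any of them stops being tolerated.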